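From 3-chlorophenyl to isoquinolin-1-yl

The source may report more compounds than this note shows. Statements on the series, on what has been measured and on what is new or still open speak of the compounds shown alone.

In a functional assay on THP-1 cells (Homo sapiens) for inhibition (a higher number here means a weaker inhibitor, a lower number a stronger inhibitor), compound 1 (`O=C(CN1CC=CC[C@H](NC(=O)c2cccc(Cl)c2)C1=O)N[C@H]1CC(=O)OC1O`) gives 383 nM and is the weaker of the two measured inhibitors, with compound 2 (`O=C[C@H](CC(=O)O)NC(=O)[C@@H]1CC[C@@H]2C/C=C\C[C@H](NC(=O)c3nccc4ccccc34)C(=O)N21`) at 188 nM lower by more than the usual scatter. Compound 3 (`O=C(CN1CC=CC[C@H](NC(=O)c2nccc3ccccc23)C1=O)N[C@H]1CC(=O)OC1O`) keeps the core of compound 1 but carries isoquinolin-1-yl in place of 3-chlorophenyl on a carbonyl carbon. Compound 2 also carries isoquinolin-1-yl, on a different core, so its 188 nM is only a loose guide. A small move toward a lower number is expected in this assay and may stay within the scatter. The expected size is a 1.5-fold lower number from compound 1 to compound 3 (0.19 log units; within the scatter) on this estimate. Compound 3 is estimated at 250 nM with 90 nM to 700 nM as its expected range.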

Compound 3, half-maximal inhibitory concentration: 586 nM
Compound 3: the middle estimate sits 2.3-fold (0.37 log units) below what was measured; low and high end bracket the measured number.
By their numbers in this assay, from the lowest: compound 2; then compounds 1 and 3 (each within the scatter of the next).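

In this assay, placing isoquinolin-1-yl in place of 3-chlorophenyl on a carbonyl carbon gives a 1.5-fold higher number from compound 1 to compound 3 (0.18 log units; within the scatter). On the core of compound 1, this position therefore accepts a second aromatic ring and a hydrogen-bond acceptor with no change beyond the scatter. Nothing available explains why the two groups read alike.

On these data alone, it remains open whether a group of a different kind here, such as an amine or a carboxylic acid, would move the number beyond the scatter. The same swap also cannot be read on the core of compound 2, which is shown only with isoquinolin-1-yl.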